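Swapping the Hydroxyphenyl for a Thiazole in Compound 4

A few compounds are considered here, and "the series" means these few. Any claim that something is new, unique, unknown or untested is made for them only; others in the source may bear on it.

Of the compounds shown here, three have so far been measured in a functional assay on HEK293 cells for agonist activity at D(4) dopamine receptor (Homo sapiens), read by FLIPR; on this read-out higher numbers stand for an effect only at larger amounts of compound and lower numbers for an effect already at smaller amounts. Compound 1 `O=C(CN1CCC(c2cccc[n+]2[O-])CC1)Nc1cccc(Cl)c1` gives 62 nM, compound 2 `Cc1cccc(NC(=O)CN2CCC(c3ccccc3C#N)CC2)c1` gives 8 nM, and compound 3 `Cc1cccc(NC(=O)CN2CCC(c3ccc(O)cc3)CC2)c1` gives 70 nM. Compound 3 thus holds the highest of the three numbers; its value and that of compound 1 lie within the scatter of each other, whereas the step of an 8.8-fold higher number from compound 2 to compound 3 (0.94 log units; beyond the scatter) lies beyond it. Compound 4 `Cc1cccc(NC(=O)CN2CCC(c3nccs3)CC2)c1` remains unmeasured and differs from compound 3 in one place: 1,3-thiazol-2-yl in place of 4-hydroxyphenyl on a saturated ring carbon. Among the measured compounds shown here, the only measured step touching this position is an 8.8-fold higher number from compound 2 to compound 3 (0.94 log units; beyond the scatter), in which the 4-hydroxyphenyl entered and the number rose. Taking that group away again is expected to bring the number partway back, so for compound 4 a step of a 2.3-fold lower number from compound 3 to compound 4 (0.37 log units; beyond the scatter) is expected. Compound 4 is therefore estimated at 30 nM, within 8 nM to 110 nM.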

Compound 4, half-maximal effective concentration: 1 nM
For compound 4 the middle estimate is 30-fold (1.48 log units) above the measured one, outside the stated range (below it).
By their numbers in this assay, from the lowest: compound 4; then compound 2; then compounds 1 and 3 (each within the scatter of the next).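

The group on this saturated ring carbon can lower the number as well as raise it: a 70-fold lower number from compound 3 to compound 4 (1.85 log units; beyond the scatter) is a large move, and the same 1,3-thiazol-2-yl also improves on the 2-cyanophenyl, with an 8.0-fold lower number from compound 2 to compound 4 (0.90 log units; beyond the scatter) as the step. Of the three groups compared here, the one with a five-membered aromatic ring gives the lowest number, so a six-membered aromatic ring of carbon only is not needed at this position. Nothing at hand explains this difference. On these data alone, whether a thiophene or an oxazole would keep the number as low remains open, as does whether the 1,3-thiazol-2-yl would have the same effect on the core of compound 1.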